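The compounds below may be only part of what the source reports. "The series", "measured", "known", "first", "only" and "open" are said of these compounds alone.

Among the measured compounds shown here, compound 1 `CN(C)C(=O)CNC(=O)c1cn(Cc2ccc(-n3cccn3)cc2)c2cccnc12` is one of three compounds measured so far in an ADME assay on liver for metabolic stability, with Liver microsome (Homo sapiens) as the target, using microsomes; a lower number here means slower removal, a higher number faster removal of the compound. In this assay compound 1 gives 9.3 mL/min/kg, the lowest of the three numbers. Compound 2 `Cn1ccc(-c2ccc(Cn3cc(C(=O)N[C@H]4CCOC[C@@H]4O)c4ncccc43)cc2)n1` shares the core of compound 1 and carries a different amide substituent; in this assay compound 2 gives 10.6 mL/min/kg, which lies within the scatter of the number for compound 1. Compound 3 `O=C(N[C@H]1CCCC[C@@H]1O)c1cn(Cc2ccc(-n3cccn3)cc2)c2ccccc12` carries the 2-hydroxycyclohexyl group on an amide-type nitrogen but sits on a different core; in this assay compound 3 gives 42 mL/min/kg, beyond the scatter above compound 1.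

Compound 4 `O=C(N[C@H]1CCCC[C@@H]1O)c1cn(Cc2ccc(-n3cccn3)cc2)c2cccnc12` has not yet been measured. It differs from compound 1 in one place: 2-hydroxycyclohexyl in place of (dimethylcarbamoyl)methyl on an amide-type nitrogen. So compound 4 joins the core of compound 1 with the amide substituent of compound 3. For the measured compounds named here, no single-change step between measured compounds covers this replacement, so the size of the step is a guess: a rise is expected, since compound 3 with the same 2-hydroxycyclohexyl group gives 42 mL/min/kg, while the core of compound 1 gives the lower numbers seen for compound 1 and compound 2. The expected step in this assay from compound 1 to compound 4 is a 2.2-fold higher number from compound 1 to compound 4 (0.33 log units; beyond the scatter). Compound 4 is estimated to give 20 mL/min/kg, with a range from 9 mL/min/kg to 45 mL/min/kg.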

Compound 4, clearance: 59 mL/min/kg
The estimate for compound 4 lay 3.0-fold (0.47 log units) below the measured number; the measured number lies above the stated range.
By their numbers in this assay, from the lowest: compounds 1 and 2 (each within the scatter of the next); then compounds 3 and 4 (each within the scatter of the next).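

In this assay, among the compounds shown here, 2-hydroxycyclohexyl in place of (dimethylcarbamoyl)methyl on an amide-type nitrogen gives a 6.3-fold higher number from compound 1 to compound 4 (0.80 log units; beyond the scatter), which makes this the only single-change reading at this position and puts the change beyond the scatter. On the core of compound 1, the number does not stay low with this group: compound 4 gives 59 mL/min/kg, within the scatter of compound 3 at 42 mL/min/kg, which carries the same group on a different core. In this pair, the change of core therefore makes no difference beyond the scatter, so the low number of compound 1 cannot be credited to its core alone. Nothing at hand explains why the number moves with this change.

The compounds shown do not separate the carbon ring of 2-hydroxycyclohexyl from its hydroxyl, and a plain cyclohexyl or a 2-hydroxyethyl group on the same nitrogen would bear on that. They also leave open whether (dimethylcarbamoyl)methyl would give a low number on the core of compound 3.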